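Moving the Hydroxy Group on the Aromatic Ring

The compounds below may be only part of what the source reports. "The series", "measured", "known", "first", "only" and "open" are said of these compounds alone.

Compound 1 `O=C1CSC(c2cccc(Cl)c2)N1CCN1CCCCC1` carries a chloro group on its aromatic ring; in an ADME assay on Vero cells (Chlorocebus sabaeus) for cytotoxicity, read by neutral red uptake, tested at 25 ug/mL (on this read-out higher numbers stand for a weaker effect at the one concentration tested and lower numbers for a stronger effect), compound 1 gives 100%. Compound 2 `O=C1CSC(c2cccc(O)c2)N1CCN1CCCCC1` has hydroxy in place of chloro on an aromatic carbon, and in this assay compound 2 gives 100%. The step of no change at the digits printed from compound 1 to compound 2 (within the scatter) shows that this swap left the read-out unchanged, so compound 2 stands level with compound 1 on the numbers at hand. Compound 3 `O=C1CSC(c2ccc(O)cc2)N1CCN1CCCCC1` is not yet measured. It differs from compound 2 in one place: 4-hydroxyphenyl in place of 3-hydroxyphenyl on a saturated ring carbon. Going by the values given here, the only measured step, no change at the digits printed from compound 1 to compound 2 (within the scatter), concerns a different kind of change and was flat, so nothing here points to a shift in either direction. The step expected here, no change at the digits printed from compound 2 to compound 3 (within the scatter), is none beyond the scatter. Compound 3 is therefore estimated at 100% in this assay, within a range from 85% to 110%.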

Compound 3, a percentage reported as activity, at one concentration (the size of the read-out at that concentration, not a potency): 100%
Beside the measured number, compound 3's estimate shows no gap at the digits printed; the range from low to high includes it.
By their numbers in this assay, from the lowest: compounds 1, 2 and 3 (each within the scatter of the next).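

In this assay, the step is no change at the digits printed from compound 2 to compound 3 (within the scatter), so at the one concentration tested this read-out does not separate 3-hydroxyphenyl from 4-hydroxyphenyl on the saturated ring carbon. The earlier step changed only the kind of group on the aromatic ring, whereas 4-hydroxyphenyl in place of 3-chlorophenyl changes both the group and where it sits, and the result is still no change at the digits printed from compound 1 to compound 3 (within the scatter). Nothing at hand speaks to why the read-out stays flat across these changes.

The compounds shown leave open whether an amine or a carboxylic acid on the aromatic ring would leave the read-out just as flat. The same question stands for a longer chain such as butyl at that ring.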